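Cyano for Chloro on a Long-Lasting Compound

The source may hold more compounds than are shown below. What is called first, only, known or untested is meant among the compounds shown, and "the series" means these compounds.

In an ADME assay on microsomes from liver (Homo sapiens) for metabolic stability (a higher number here means that the compound lasts longer, a lower number that the compound disappears faster), compound 1 `NS(=O)(=O)CC(=O)NCCSc1nonc1/C(=N/O)Nc1cccc(Cl)c1` gives > 3 h, which is a limit of the assay and not a number. Two related compounds do have numbers: compound 2 `C[C@H](CSc1nonc1/C(=N/O)Nc1ccc(F)c(Br)c1)NC(=O)CS(N)(=O)=O` gives 0.77 h and compound 3 `C[C@@H](CSc1nonc1/C(=N/O)Nc1ccc(F)c(Br)c1)NC(=O)CS(N)(=O)=O` gives 1.57 h.

Compound 4 `N#Cc1cccc(N/C(=N\O)c2nonc2SCCNC(=O)CS(N)(=O)=O)c1` has not yet been measured. It keeps the core of compound 1 and changes one group: cyano in place of chloro on an aromatic carbon. This places cyano in place of chloro on an aromatic carbon, turning 3-chlorophenyl into 3-cyanophenyl.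

Within the data shown here, the only measured step is a 2.0-fold higher number from compound 2 to compound 3 (0.31 log units; beyond the scatter), and it comes with the fact that compounds 2 and 3 differ only in the configuration as drawn. It swaps no group, so it shows how far a small structural change can move the half-life here, but it gives no direction for chloro to cyano. With no direct evidence, no step beyond the scatter is expected in this assay. The expected change is an at least 1.2-fold lower number from compound 1 to compound 4 (0.07 log units; that floor lies within the scatter). For compound 4 the estimated half-life is 2.5 h, with an expected range from 1 h to 5 h.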

Compound 4, half-life: > 3 h
Compound 4: no number, only a limit; the forecaster's own chance of this, stated with the estimate: 40%; at least 1.2-fold (0.07 log units) between middle value and limit.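

No step can be read between compound 1 and compound 4 in this assay, because neither has a number, only a limit: the limit of > 3 h in this assay, at which 2 of the 4 values shown sit.

The compounds shown leave open how long either one really lasts, and so whether cyano in place of chloro moves the half-life at all.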